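The compounds below may be only part of what the source reports. "The series", "measured", "known", "first", "only" and "open" are said of these compounds alone.

Measured so far, in an ADME assay on HELF cells (Homo sapiens) for cytotoxicity, with a stated time of 3 days; a lower number here means that less compound is tolerated, a higher number that more compound is tolerated:
compound 1 `C[C@H](NC(=O)[C@@]1(Cc2ccccc2)CCN1C(=O)OCc1ccccc1)C(=O)NC(C)(C)C` — compound 1 gives > 100000 nM, a limit of the assay.
compound 2 `C[C@H](NC(=O)[C@@]1(Cc2ccccc2)CCN1C(=O)OCc1ccccc1)C(=O)N(C)C` — compound 2 gives > 100000 nM, also a limit of the assay.
compound 3 `C[C@H](NC(=O)[C@@]1(Cc2ccccc2)CCN1C(=O)OCc1ccccc1)C(=O)NC1CCCCC1` — compound 3 gives 100000 nM, the only number in the series.

Among the compounds with values here, compound 3 thus stands as the sole measured number; the other two values are limits, see (the limit of > 100000 nM in this assay, at which 2 of the 3 values shown sit). The steps of a number no higher from compound 1 to compound 3 (the limit leaves the size open) and a number no higher from compound 2 to compound 3 (the limit leaves the size open) both end at compound 3 and neither has a readable size. The step that the two limits leave unreadable from compound 1 to compound 2 joins two limits and cannot be read at all.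

Compound 4 `CC(C)C[C@H](NC(=O)[C@@]1(Cc2ccccc2)CCN1C(=O)OCc1ccccc1)C(N)=O` is not yet measured. It differs from compound 3 by 1-carbamoyl-3-methylbutyl in place of 1-(cyclohexylcarbamoyl)ethyl on an amide-type nitrogen. Within the data shown here, no measured step replaces the whole group on this amide-type nitrogen; the steps into compound 3 alter only the amide substituent, and none gives a readable size. Among the measured compounds shown here, with all three measured values at the limit or at the single number next to it, no change beyond the scatter is expected in this assay. The step of no change at the digits printed from compound 3 to compound 4 (within the scatter) is expected to be flat. Compound 4 is expected at 100000 nM, range 50000 nM to 200000 nM, with a fair chance that only a limit is reported.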

Compound 4, minimum cytotoxic concentration: > 100000 nM
Compound 4 ended at the assay's limit (the forecaster's own chance of this, stated with the estimate: 60%); the middle value lies on the limit itself.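

In this assay the change now reaches beyond the amide substituent: 1-carbamoyl-3-methylbutyl on the amide-type nitrogen removes the six-membered ring of 1-(cyclohexylcarbamoyl)ethyl and alters the chain as well, yet compound 4 still gives only a limit. The result is a number no lower from compound 3 to compound 4 (the limit leaves the size open) and neither this step nor those into compound 4 from compound 1 and compound 2 can be read for size. Even with this larger replacement, the values stay at the limit, with compound 3 alone carrying a number: the limit of > 100000 nM in this assay, at which 3 of the 4 values shown sit.

Where a number would appear for a carboxylic acid or a primary amine on this chain remains open. Any lower limit of tolerance in this assay for such groups is equally undefined by the compounds shown.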